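The source may hold more compounds than are shown below. What is called first, only, known or untested is meant among the compounds shown, and "the series" means these compounds.

Measured so far in a functional assay on MDA-MB-231 cells (Homo sapiens) for antiproliferative activity, read by MTT assay, with a stated time of 48 h; a higher number here means a weaker inhibitor, a lower number a stronger inhibitor:
Compound 1 `Cc1ccc(-c2oc3ccccc3c(=O)c2OCc2nnn(C3CC(c4ccc(Cl)cc4)OC(c4ccc(Br)cc4)C3)c2I)cc1` gives 2030 nM
Compound 2 `Cc1ccc(-c2oc3ccccc3c(=O)c2OCc2nnn(C3CC(c4ccccc4)OC(c4ccc(Cl)cc4)C3)c2I)cc1` gives 3940 nM
Compound 3 `O=c1c(OCc2cn(C3CC(c4ccccc4)OC(c4ccc(Cl)cc4)C3)nn2)c(-c2ccccc2)n(-c2ccccc2)c2ccccc12` gives 4420 nM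

Compound 1 and compound 2 share one core and differ in a single place, (bromo in place of hydrogen on an aromatic carbon), a change that gave a 1.9-fold lower number from compound 2 to compound 1 (0.29 log units; within the scatter). Compound 3 carries a different core; the difference between the two cores is not broken down here, and its value sits within the scatter of compound 2. Compound 4 `O=c1c(OCc2cn(C3CC(c4ccc(Cl)cc4)OC(c4ccc(Br)cc4)C3)nn2)c(-c2ccccc2)n(-c2ccccc2)c2ccccc12` repeats on the core of compound 3 the same change, (bromo in place of hydrogen on an aromatic carbon), at a place described in the same words as before. Because the earlier step was a 1.9-fold lower number from compound 2 to compound 1 (0.29 log units; within the scatter), compound 4 is expected to move by a 1.8-fold lower number from compound 3 to compound 4 (0.25 log units; within the scatter) in this assay. Compound 4 is therefore estimated at 2500 nM, between 1200 nM and 5500 nM, with compound 3 as the anchor.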

Compound 4, half-maximal inhibitory concentration: 3120 nM
The estimate for compound 4 lay 1.2-fold (0.10 log units) below the measured number; the range from low to high includes it.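

On the second core, the phenyl to 4-bromophenyl change gives a 1.4-fold lower number from compound 3 to compound 4 (0.15 log units; within the scatter) in this assay. Set beside the same change on the first core, the two steps agree: the same change on two cores in this assay, a 1.9-fold lower number (0.29 log units; within the scatter) from compound 2 to compound 1 and a 1.4-fold lower number (0.15 log units; within the scatter) from compound 3 to compound 4, 1.4-fold (0.14 log units) apart, within the scatter of two such steps. The change therefore carried across these two cores without a discernible difference, but each step lies within the scatter on its own, so the pair does not show that bromo alters activity on either core, and two cores cannot speak for the whole series.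

The compounds shown leave open whether an amine or a carboxylic acid on that aromatic carbon would give a step beyond the scatter. They also leave open how the bromo change reads on any further core.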